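The compounds below may be only part of what the source reports. "The series", "measured", "known", "first", "only" and "open" are said of these compounds alone.

Compound 1 `O=C1N=C(N2N=C(c3ccccc3)CC2c2ccc(Cl)cc2)S/C1=C1/C(=O)Nc2ccccc21` and compound 2 `COc1ccc(C2=NN(C3=NC(=O)/C(=C4\C(=O)Nc5ccccc54)S3)C(c3ccc(Cl)cc3)C2)cc1` share one core and differ in a single spot. In a functional assay on cells (Melanoma cell, Homo sapiens) for cytotoxicity, read by sulforhodamine B assay, with a stated time of 48 h (on this read-out higher numbers stand for weaker inhibition of growth and lower numbers for stronger inhibition of growth), compound 1 gives 540 nM, whereas compound 2 gives 100000 nM. The step of a 190-fold higher number from compound 1 to compound 2 (2.27 log units; beyond the scatter) is large and shows that putting a methoxy where hydrogen stood weakened growth inhibition strongly. Among the two measured compounds, compound 2 stands at the highest number, with compound 1 as its only neighbour far below.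

Compound 3 `O=C1N=C(N2N=C(c3ccc4ccccc4c3)CC2c2ccc(Cl)cc2)S/C1=C1/C(=O)Nc2ccccc21` takes the change (naphthalen-2-yl in place of 4-methoxyphenyl on a carbon with a double bond to nitrogen). Among the measured compounds shown here, this removes the methoxy that marked compound 2 and at the same time adds a second fused aromatic ring that no measured compound carries. For the measured compounds named here, the only step that bears on it is a 190-fold higher number from compound 1 to compound 2 (2.27 log units; beyond the scatter), which points to a large recovery once the methoxy is gone, but the added ring is untested, so the size of that recovery is uncertain. On this basis compound 3 is expected to show a step of a 40-fold lower number from compound 2 to compound 3 (1.60 log units; beyond the scatter) in this assay, a large improvement but not necessarily all the way back to compound 1. The estimate for compound 3 is 2500 nM, within a range from 400 nM to 30000 nM.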

Compound 3, concentration for total growth inhibition: 24700 nM
The estimate for compound 3 lay 9.9-fold (0.99 log units) below the measured number; low and high end bracket the measured number.
By their numbers in this assay, from the lowest: compound 1; then compound 3; then compound 2.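

In this assay, naphthalen-2-yl in place of 4-methoxyphenyl on the carbon with a double bond to nitrogen gives a 4.0-fold lower number from compound 2 to compound 3 (0.61 log units; beyond the scatter), a modest gain that shows that losing the methoxy does not by itself bring growth inhibition back. Set against the plain phenyl, the same group gives a 46-fold higher number from compound 1 to compound 3 (1.66 log units; beyond the scatter), a large loss. Both replacements of phenyl shown here therefore raise the number, one carrying a methoxy and the other a second aromatic ring with no oxygen, so the loss at this position does not depend on the methoxy alone, and among these three compounds phenyl gives the lowest number.

Nothing measured here explains why these groups rank as they do. The compounds shown leave open whether a phenyl ring bearing a single fluorine or a hydroxyl, or a saturated cyclohexyl ring in place of the phenyl, would keep the growth inhibition of compound 1 or lose it as these two replacements did.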